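The source may hold more compounds than are shown below. What is called first, only, known or untested is meant among the compounds shown, and "the series" means these compounds.

Compound 1 `CC1=C(C(=O)OCc2ccccc2)C(c2ccco2)NC(=O)N1` is a small ester built on a shared core, and in an assay on membranes from HeLa cells for displacement of a labelled ligand from adenosine receptor A3 (Homo sapiens), read by scintillation counting, with a stated time of 180 min, tested at 1 uM (on this read-out lower numbers stand for less inhibition and higher numbers for more inhibition at the one concentration tested (going by the name of the read-out)), compound 1 gives 3%. Compound 2 `CC1=C(C(=O)OCc2ccccc2)C(c2cccs2)NC(=O)N1` gives 8% in this assay. Compound 1 stands at the bottom of these two numbers, but the step of a number 5 percentage points higher from compound 1 to compound 2 (within the scatter) lies within the scatter, so the two cannot be told apart. Compound 3 `CC1=C(C(=O)OC2CCC2)C(c2ccco2)NC(=O)N1` has not yet been measured; it differs from compound 1 in one place: cyclobutyl in place of benzyl on an oxygen next to a carbonyl group. For the measured compounds named here, the only measured step concerns a different part of the molecule and is itself within the scatter, so nothing recorded speaks directly to the ester change. With no step beyond the scatter anywhere in the set, and both known numbers low, compound 3 is expected to stay near compound 1, a step of a number 2 percentage points higher from compound 1 to compound 3 (within the scatter) that should fall within the scatter. Compound 3 is therefore estimated at 5% in this assay, between 0% and 15%.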

Compound 3, a percentage reported as inhibition, at one concentration (the size of the read-out at that concentration, not a potency): 1%
Compound 3: the middle estimate sits 4 percentage points above what was measured; the range from low to high includes it.
By their numbers in this assay, from the lowest: compounds 3, 1 and 2 (each within the scatter of the next).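

Cyclobutyl in place of benzyl on an oxygen next to a carbonyl group gives a number 2 percentage points lower from compound 1 to compound 3 (within the scatter) in this assay, the first reading for a change at this place on the molecule. At the one concentration tested, the one-ring groups with a six-membered aromatic ring of carbon only and a four-membered non-aromatic ring of carbon only therefore cannot be told apart, and the number stays low with either of them. No measurement at hand offers a reason for this reading.

Still open, from the compounds shown here alone, is whether any group on this oxygen can lift the number clear of the scatter, for example a longer chain such as n-hexyl or a chain that carries an amine. Also open, going by these compounds, is whether cyclobutyl reads the same alongside thiophen-2-yl as alongside furan-2-yl.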